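Plasma half-life of salicylate esters: a sulfinyl substituent

The source may report more compounds than this note shows. Statements on the series, on what has been measured and on what is new or still open speak of the compounds shown alone.

Measured compounds:
compound 1 `CC(=O)Oc1ccccc1C(=O)OCC(=O)N(C)CCO` 0.0633 h
compound 2 `CCNC(=O)COC(=O)c1ccccc1OC(C)=O` 0.045 h
compound 3 `COC(=O)c1ccccc1OC(C)=O` 0.0533 h

In an ADME assay on the whole organism (plasma) with Homo sapiens as the target (on this read-out higher numbers stand for a longer-lived compound and lower numbers for a shorter-lived compound), compound 3 gives 0.0533 h. Of the three measured numbers this is neither separated from compound 2 nor from compound 1: the step of a 1.2-fold higher number from compound 2 to compound 3 (0.07 log units; within the scatter) and the step of a 1.2-fold lower number from compound 1 to compound 3 (0.07 log units; within the scatter) both lie within the scatter, so compound 3 cannot be told apart from either companion on this read-out.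

Compound 4 `CC(=O)Oc1ccccc1C(=O)OC[S+](C)[O-]` is the next member. It differs from compound 3 by a group of 3 heavy atoms (1 carbon, 1 oxygen, 1 sulfur; no ring) in place of a hydrogen atom, on a saturated chain carbon bound to an oxygen next to a carbonyl group. Two of the measured steps touch that same carbon: a 1.2-fold lower number from compound 1 to compound 3 (0.07 log units; within the scatter) and a 1.2-fold higher number from compound 2 to compound 3 (0.07 log units; within the scatter), each replacing a larger substituent there by hydrogen, and neither moved the number beyond the scatter. Compound 1 and compound 2 also sit within the scatter of each other, as a 1.4-fold lower number from compound 1 to compound 2 (0.15 log units; within the scatter) shows. On that basis the substituent on this carbon is expected to leave the half-life essentially unchanged, and the step of a 1.0-fold lower number from compound 3 to compound 4 (0.00 log units; within the scatter) is expected to stay within the scatter. Compound 4 is therefore estimated at 0.053 h, with a range from 0.027 h to 0.105 h.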

Compound 4, half-life in the Homo sapiens assay: 0.055 h
Compound 4: the middle estimate sits 1.0-fold (0.02 log units) below what was measured; the range from low to high includes it.
By their numbers in the Homo sapiens assay, from the lowest: compounds 2, 3, 4 and 1 (each within the scatter of the next).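

On the saturated chain carbon bound to an oxygen next to a carbonyl group, the group of 3 heavy atoms also fails to separate compound 4 from any earlier compound in the Homo sapiens assay: the steps are a 1.0-fold higher number from compound 3 to compound 4 (0.01 log units; within the scatter), a 1.2-fold higher number from compound 2 to compound 4 (0.09 log units; within the scatter) and a 1.2-fold lower number from compound 1 to compound 4 (0.06 log units; within the scatter). In a physicochemical assay for solubility, at 21 degrees C (on this read-out lower numbers stand for lower solubility and higher numbers for higher solubility), compound 3 gives 2810 ug/mL and compound 4 gives 4230 ug/mL, and a 1.5-fold higher number from compound 3 to compound 4 (0.18 log units; within the scatter) shows that this change does not separate the pair on this second read-out either. No supporting data bear on these results.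

From the compounds shown here alone, whether an amine, a carboxylic acid or a longer chain on this carbon would move the half-life beyond the scatter remains open. The compounds shown also leave open what a change elsewhere on the shared core would do.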